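Methoxy on the Phenoxy Ring: Expected Aromatase Inhibition

This account rests on a few compounds, and the source may have more. Where it says the series, first, only, none or still open, it means among the compounds named here.

Three compounds sharing one core have been measured in an assay on isolated protein for inhibition of Aromatase (Homo sapiens), read by fluorescence and colorimetric assay, with a stated time of 30 min; a higher number here means a weaker inhibitor, a lower number a stronger inhibitor:

Compound 1, `N#Cc1ccc(C(c2ccc(C#N)cc2)n2cc(COc3ccccc3)nn2)cc1`: 11000 nM
Compound 2, `N#Cc1ccc(C(c2ccc(C#N)cc2)n2cc(COc3ccc(Cl)cc3)nn2)cc1`: 16100 nM
Compound 3, `N#Cc1ccc(C(c2ccc(C#N)cc2)n2cc(COc3ccc([N+](=O)[O-])cc3)nn2)cc1`: 7730 nM

Among these three numbers compound 1 stands second highest. Its nearest neighbour is compound 3, reached by a step of a 1.4-fold lower number from compound 1 to compound 3 (0.15 log units; within the scatter), and the furthest is compound 2, reached by a step of a 1.5-fold higher number from compound 1 to compound 2 (0.17 log units; within the scatter). Among the measured compounds shown here, both steps lie within the scatter, so the three values cannot be ordered with confidence; only the step of a 2.1-fold lower number from compound 2 to compound 3 (0.32 log units; beyond the scatter) is printed as modest and beyond the scatter.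

Compound 4, `COc1ccc(OCc2cn(C(c3ccc(C#N)cc3)c3ccc(C#N)cc3)nn2)cc1`, has not yet been measured in this assay. It differs from compound 1 by methoxy in place of hydrogen on an aromatic carbon. The two measured steps that bear on this change are those in which a chloro or a nitro group took the same place on the same ring, and neither moved the number beyond the scatter. A methoxy group at that place is therefore expected to behave alike, giving a step of a 1.1-fold lower number from compound 1 to compound 4 (0.04 log units; within the scatter) that stays within the scatter. For compound 4 the estimate is 10000 nM, with a range from 5000 nM to 22000 nM.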

Compound 4, half-maximal inhibitory concentration: 12200 nM
Beside the measured number, compound 4's estimate is 1.2-fold (0.09 log units) below it, and the stated range covers the measured number.
By their numbers in this assay, from the lowest: compounds 3, 1, 4 and 2 (each within the scatter of the next, the first and the last beyond it).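

With methoxy, this place on the ring now holds three different groups, and none gives a number that can be told apart from the one with hydrogen: in this assay the new step is a 1.1-fold higher number from compound 1 to compound 4 (0.04 log units; within the scatter). Methoxy also cannot be separated from nitro (a 1.6-fold higher number from compound 3 to compound 4 (0.20 log units; within the scatter)) or from chloro (a 1.3-fold lower number from compound 2 to compound 4 (0.12 log units; within the scatter)), so the only step printed as beyond the scatter in this set is still the modest one, a 2.1-fold lower number from compound 2 to compound 3 (0.32 log units; beyond the scatter). No further measurement on these compounds is at hand to explain why the numbers lie so close together.

The compounds shown leave open whether a group of another kind at this place, such as an amine, a carboxylic acid or a longer chain like butoxy, would give a number clearly apart from that of compound 1. They also leave open whether methoxy, chloro or nitro would give similarly close numbers at other places on the same ring, since each substituted compound here carries its group at the one place.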